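The source may hold more compounds than are shown below. What is called first, only, known or untested is meant among the compounds shown, and "the series" means these compounds.

Working notes on the series in an ADME assay on HOS cells (Homo sapiens) for cytotoxicity (on this read-out lower numbers stand for stronger inhibition and higher numbers for weaker inhibition), begin with how little has been measured. Compound 1 (`O=C1c2c(ccc(O)c2O)CN1Cc1ccccc1`) stands at "not determined" (no result reported) in this assay and so gives no single number to start from. Compound 2 (`O=C1c2c(ccc(O)c2O)CN1Cc1ccc(F)cc1`) is in the same position, as compound 2 also reads "not determined" (no result reported) there. Within the data shown here, the only number comes from compound 3 (`O=C1c2ccc(O)c(O)c2C(=O)N1Cc1cccc(Cl)c1`), and compound 3 gives 13300 nM in this assay as the sole anchor for the series.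

Next to be measured is compound 4 (`O=C1c2c(ccc(O)c2O)CN1Cc1cccc(Br)c1`), which keeps the core of compound 1 with a single change. That change is bromo in place of hydrogen on an aromatic carbon and in words it is bromo in place of hydrogen on an aromatic carbon, meta to a large group. Among the measured compounds shown here, no measured pair shows a step of this kind, and without a number for compound 1 no direction can be assigned to the step in this assay. For the measured compounds named here, the working expectation is therefore no gap beyond the scatter from the one available reading, compound 3 at 13300 nM in this assay. Compound 4 is estimated at 15000 nM with an expected range from 5000 nM to 50000 nM in this read-out.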

Compound 4, half-maximal inhibitory concentration: 7240 nM
Compound 4: the middle estimate sits 2.1-fold (0.32 log units) above what was measured; low and high end bracket the measured number.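

No new step can be read in this assay, as compound 1 has no single number to set against compound 4. The compounds shown leave open whether bromo in place of hydrogen shifts the read-out at all, and by how much. No supporting evidence bears on the result for compound 4.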